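Urea Substituent Variation in an Antiproliferative Series

This account rests on a few compounds, and the source may have more. Where it says the series, first, only, none or still open, it means among the compounds named here.

Measured compounds:
compound 1, `CCCNc1nc2ccc(-c3cnc(Cl)c(NS(=O)(=O)c4ccc(F)cc4)c3)cc2s1` — "not determined" (no result reported)
compound 2, `O=C(Nc1nc2ccc(-c3cnc(Cl)c(NS(=O)(=O)c4ccc(F)cc4)c3)cc2s1)NC1CC1` — 1030 nM

Two compounds share the same core. Compound 1 `CCCNc1nc2ccc(-c3cnc(Cl)c(NS(=O)(=O)c4ccc(F)cc4)c3)cc2s1` carries a propylamino group on it, and in a functional assay on A549 cells (Homo sapiens) for antiproliferative activity, read by MTT assay, with a stated time of 72 h (a higher number here means a weaker inhibitor, a lower number a stronger inhibitor), compound 1 gives "not determined" (no result reported), so no result was reported for it. Compound 2 `O=C(Nc1nc2ccc(-c3cnc(Cl)c(NS(=O)(=O)c4ccc(F)cc4)c3)cc2s1)NC1CC1` carries a (cyclopropylcarbamoyl)amino group and, in this assay, compound 2 gives 1030 nM. This is the only number shown, so compound 2 stands alone on it and no step between measured compounds is available.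

Compound 3 `CCN(CC)CCNC(=O)Nc1nc2ccc(-c3cnc(Cl)c(NS(=O)(=O)c4ccc(F)cc4)c3)cc2s1` differs from compound 2 in one place: 2-(diethylamino)ethyl in place of cyclopropyl on an amide-type nitrogen. Within the data shown here, with no measured step to rest on, the expected change from compound 2 to compound 3 in this assay is a 1.5-fold higher number from compound 2 to compound 3 (0.16 log units; within the scatter), which is estimated to be small, at most a modest shift toward a weaker inhibitor, and possibly none beyond the scatter. Compound 3 is therefore expected to give about 1500 nM, estimated within the range 400 nM to 6000 nM.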

Compound 3, half-maximal inhibitory concentration: 5260 nM
Compound 3: the middle estimate sits 3.5-fold (0.54 log units) below what was measured; the range from low to high includes it.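

Among these compounds, this is the first step that can be read: in this assay there is a 5.1-fold higher number from compound 2 to compound 3 (0.71 log units; beyond the scatter). The group on this amide-type nitrogen therefore matters to the read-out, and the exchange of the cyclopropyl ring for the open 2-(diethylamino)ethyl chain goes with a weaker inhibitor, although compound 3 still gives a number of 5260 nM. Nothing measured on these compounds offers an explanation for the step.

The compounds shown leave open whether the loss of the ring, the longer chain or the added nitrogen goes with this change, and a plain hexyl chain or a cyclohexyl group on the same nitrogen would help to separate these. Going by these compounds, it also remains open how a carboxylic acid at the end of the chain would compare.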